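Triazole Amides Bearing Varied Aryl Groups Against Liver Cells

A few compounds are considered here, and "the series" means these few. Any claim that something is new, unique, unknown or untested is made for them only; others in the source may bear on it.

Compound 1 `COc1ccc(-n2nncc2CN2C(=O)C3(C(C#N)=C(N)Oc4c3c3nc5ccccc5nc3c3ccccc43)c3ccccc32)cc1`: in a functional assay on HepG2 cells (Homo sapiens) for antiproliferative activity, read by MTT assay, with a stated time of 48 h (on this read-out higher numbers stand for weaker inhibition and lower numbers for stronger inhibition), compound 1 gives only the assay limit > 50000 nM.
Compound 2 `COc1ccccc1-n1nncc1CN1C(=O)C2(C(C#N)=C(N)Oc3c2c2nc4ccccc4nc2c2ccccc32)c2ccccc21`: in this assay compound 2 gives only the assay limit > 50000 nM.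
Compound 3 `CCOc1ccccc1-n1nncc1CN1C(=O)C2(C(C#N)=C(N)Oc3c2c2nc4ccccc4nc2c2ccccc32)c2ccccc21`: in this assay compound 3 gives only the assay limit > 50000 nM.

Compound 3 therefore stands at the limit of this assay, not at a number, and it shares this position with every other measured compound, as the limit of > 50000 nM in this assay, at which 3 of the 3 values shown sit, shows. The three steps among them, a step that the two limits leave unreadable from compound 1 to compound 2, a step that the two limits leave unreadable from compound 1 to compound 3 and a step that the two limits leave unreadable from compound 2 to compound 3, remain unreadable, since both ends of each sit at the same limit.

Compound 4 `N#CC1=C(N)Oc2c(c3nc4ccccc4nc3c3ccccc23)C12C(=O)N(Cc1cnnn1-c1ccc(S(N)(=O)=O)cc1)c1ccccc12` carries the change (4-sulfamoylphenyl in place of 2-ethoxyphenyl on an aromatic nitrogen). For the measured compounds named here, no measured step bears readably on this exchange, and no measured compound has yet produced a number in this assay. The expectation for compound 4 is accordingly that it, too, is most likely to return only a limit, with the step of a number no higher from compound 3 to compound 4 (the limit leaves the size open) expected to be none beyond the scatter. Compound 4 is estimated at 50000 nM, within a range from 20000 nM to 100000 nM.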

Compound 4, half-maximal inhibitory concentration: 42200 nM
Beside the measured number, compound 4's estimate is 1.2-fold (0.07 log units) above it; low and high end bracket the measured number.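

At this aromatic nitrogen, 4-sulfamoylphenyl gives the first number rather than a limit in this assay, which sets compound 4 apart from the other compounds, all of which share one limit: the limit of > 50000 nM in this assay, at which 3 of the 4 values shown sit. The exchange can now be read, though only as a floor, in three steps: an at least 1.1-fold lower number from compound 3 to compound 4 (0.07 log units; that floor lies within the scatter), an at least 1.1-fold lower number from compound 2 to compound 4 (0.07 log units; that floor lies within the scatter) and an at least 1.1-fold lower number from compound 1 to compound 4 (0.07 log units; that floor lies within the scatter). None of these is shown to go beyond the scatter, their full size stays open, and the steps among compound 1, compound 2 and compound 3 still cannot be read.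

As far as these compounds go, it remains open whether a 4-aminophenyl or a 4-carboxyphenyl group on this nitrogen would also give a number. From the compounds shown here alone, it is also open whether a sulfamoyl group carrying a methyl on its nitrogen would do so.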